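Amide substituent variation on a shared core: compound 4

A few compounds are considered here, and "the series" means these few. Any claim that something is new, unique, unknown or untested is made for them only; others in the source may bear on it.

Measured compounds
Compound 1 `Cn1cc(NC(=O)c2ccncc2Nc2cc(-c3ccc4ccn(C)c4c3)c3nccnc3c2)cn1`: 26500 nM
Compound 2 `Cn1ccc2ccc(-c3cc(Nc4cnccc4C(=O)NC4CCNC(=O)C4)cc4nccnc34)cc21`: 56500 nM
Compound 3 `CC(=O)N1CCOC(CNC(=O)c2ccncc2Nc2cc(-c3ccc4ccn(C)c4c3)c3nccnc3c2)C1`: a limit, > 100000 nM

All three share one core and differ only in the group on the amide-type nitrogen. In an assay on lysate for inhibition of 6-phosphofructo-2-kinase/fructose-2,6-bisphosphatase 3 (Homo sapiens), with stated times of 0.5 min and 45 min (on this read-out higher numbers stand for weaker inhibition and lower numbers for stronger inhibition), compound 1 gives 26500 nM and compound 2 gives 56500 nM. For compound 3 this assay reports only a limit, > 100000 nM (the limit of > 100000 nM in this assay, at which 1 of the 3 values shown sits), so compound 3 stands without a number. The steps among the measured compounds are a 2.1-fold higher number from compound 1 to compound 2 (0.33 log units; beyond the scatter), an at least 3.7-fold higher number from compound 1 to compound 3 (0.57 log units; beyond the scatter) and an at least 1.7-fold higher number from compound 2 to compound 3 (0.24 log units; that floor lies within the scatter).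

Compound 4 `CC(=O)N1CC(NC(=O)c2ccncc2Nc2cc(-c3ccc4ccn(C)c4c3)c3nccnc3c2)C1` differs from compound 3 by 1-acetylazetidin-3-yl in place of (4-acetylmorpholin-2-yl)methyl on an amide-type nitrogen. For the measured compounds named here, no measured step carries this exact change; the three measured steps show only that exchanges on the amide-type nitrogen move this assay modestly at most. Compound 4 is therefore expected to sit near compound 3, with the step of an at least 1.2-fold lower number from compound 3 to compound 4 (0.09 log units; that floor lies within the scatter) estimated as small or none beyond the scatter. The estimate for compound 4 in this assay is 80000 nM, in the range 30000 nM to 200000 nM, with a fair chance that only a limit is reported again.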

Compound 4, half-maximal inhibitory concentration: 97400 nM
Compound 4: middle estimate off by 1.2-fold (0.09 log units), on the low side; the measured number falls inside the stated range.
By their numbers in this assay, from the lowest: compound 1; then compounds 2 and 4 (each within the scatter of the next). At a limit, above all of these: compound 3.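

Compound 4 places a measured value at the weak end of this position in this assay, and the 1-methyl-1H-pyrazol-4-yl amide remains apart from the 1-acetylazetidin-3-yl amide, with a 3.7-fold higher number from compound 1 to compound 4 (0.57 log units; beyond the scatter). Exchanging 2-oxopiperidin-4-yl for 1-acetylazetidin-3-yl gives a 1.7-fold higher number from compound 2 to compound 4 (0.24 log units; within the scatter), so these two non-aromatic rings are not told apart here. The step of an at least 1.0-fold lower number from compound 3 to compound 4 (0.01 log units; that floor lies within the scatter) cannot be read as a change, the starting value being only a limit: the limit of > 100000 nM in this assay, at which 1 of the 4 values shown sits.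

Whether the separation of compound 1 extends to other aromatic rings on the amide-type nitrogen stays open, since only the 1-methyl-1H-pyrazol-4-yl group speaks to it and a phenyl or pyridyl group does not appear among the compounds shown. Going by these compounds, how a free azetidine amine in place of the acetylated ring would read in this assay also stays open.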